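A few compounds are considered here, and "the series" means these few. Any claim that something is new, unique, unknown or untested is made for them only; others in the source may bear on it.

Measured so far in a functional assay on MDA-MB-231 cells (Homo sapiens) for cytotoxicity, read by MTT assay, with a stated time of 72 h; on this read-out lower numbers stand for stronger inhibition and higher numbers for weaker inhibition:
- compound 1 `CN(C)CCCCCn1c2c(c3ccccc31)C(=O)c1c[n+]([O-])c3ccccc3c1C2=O`: 240 nM
- compound 2 `CN1CCN(CCCCn2c3c(c4ccccc42)C(=O)c2c[n+]([O-])c4ccccc4c2C3=O)CC1`: 110 nM

Of these two compounds, compound 2 has the lower number at 110 nM, so it is the stronger inhibitor on this read-out. Compound 3 `O=C1c2c[n+]([O-])c3ccccc3c2C(=O)c2c1c1ccccc1n2CCN1CCCC1` has not yet been measured. It differs from compound 2 in its side chain: pyrrolidin-1-yl in place of 2-(4-methylpiperazin-1-yl)ethyl on a saturated chain carbon, two bonds along the chain from an aromatic nitrogen. In words, pyrrolidin-1-yl stands in place of 2-(4-methylpiperazin-1-yl)ethyl, on a saturated chain carbon, two bonds along the chain from an aromatic nitrogen.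

Within the data shown here, only one measured step bears on this change: a 2.2-fold lower number from compound 1 to compound 2 (0.34 log units; beyond the scatter). It is a modest step, and it is the step that introduced 4-methylpiperazin-1-yl, the group compound 3 gives up. Among the measured compounds shown here, one step is thin evidence, and no measured compound carries pyrrolidin-1-yl. A partial return towards the higher number of compound 1, at 240 nM, therefore seems the most reasonable expectation, with wide uncertainty. The expected change is a 1.7-fold higher number from compound 2 to compound 3 (0.24 log units; within the scatter). In this assay the estimate for compound 3 is 190 nM, with an expected range from 65 nM to 550 nM.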

Compound 3, half-maximal inhibitory concentration: 630 nM
Estimate against measurement, compound 3: 3.3-fold (0.52 log units) below; the whole stated range lies below it.
By their numbers in this assay, from the lowest: compound 2; then compound 1; then compound 3.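

In this assay, among these compounds, replacing the 4-(4-methylpiperazin-1-yl)butyl side chain with 2-(pyrrolidin-1-yl)ethyl gives a 5.7-fold higher number from compound 2 to compound 3 (0.76 log units; beyond the scatter), so this change weakens inhibition, whereas the only earlier step had gone towards a lower number. Compound 3 also falls beyond the weaker of the two earlier compounds, with a 2.6-fold higher number from compound 1 to compound 3 (0.42 log units; beyond the scatter), so the change does more than undo the gain seen with compound 2. The side chain on the aromatic nitrogen can therefore move the number in either direction, and compound 3 is the weakest of the three on this read-out.

Both steps alter the amine and the length of the chain together, so the compounds shown leave open how much each contributes; a 4-(pyrrolidin-1-yl)butyl chain or a 2-(4-methylpiperazin-1-yl)ethyl chain on the shared core would pull the two apart. Nothing shown here gives a measured explanation for the higher number of compound 3.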